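The source may hold more compounds than are shown below. What is called first, only, known or untested is meant among the compounds shown, and "the series" means these compounds.

Measured compounds:
- compound 1 `O=C(O)CC/C=C\CO[C@H]1C(OCc2ccc(-c3ccc(CO)cc3)cc2)CC[C@@H]1N1CCCCCC1` gives 3.16 nM in a functional assay on blood for antagonist activity at thromboxane A2 receptor (Homo sapiens); on this read-out lower numbers stand for tighter binding and higher numbers for weaker binding
- compound 2 `CC(=O)NCc1ccccc1-c1ccc(COC2CC[C@H](N3CCCCCC3)[C@H]2OC/C=C\CCC(=O)O)cc1` gives 25.1 nM in this assay
- compound 3 `O=C(O)CC/C=C\CO[C@H]1[C@H](OCc2ccc(-c3ccccc3CO)cc2)CC[C@@H]1N1CCCCCC1` gives 6.31 nM in this assay

Compound 2 has the highest number of the three; compound 3 is the nearest, compound 1 the furthest below it. The unmeasured compound 4 `O=C(O)CC/C=C\CO[C@H]1C(OCc2ccc(-c3ccccc3)cc2)CC[C@@H]1N1CCCCCC1` differs from compound 2 by hydrogen in place of acetamidomethyl on an aromatic carbon. Within the data shown here, no measured step removes a group outright; the only related step is a 7.9-fold higher number from compound 1 to compound 2 (0.90 log units; beyond the scatter), which shows that the acetamidomethyl-bearing compound 2 is the weaker of that pair. Hence a modest step toward a lower number is expected for compound 4, though the direction is uncertain. Compound 4 is expected to give 8 nM in this assay, with a range of 2 nM to 30 nM, meaning an expected step of a 3.1-fold lower number from compound 2 to compound 4 (0.50 log units; beyond the scatter).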

Compound 4, dissociation constant: 12.6 nM
Estimate against measurement, compound 4: 1.6-fold (0.20 log units) below; measured number inside the range.
By their numbers in this assay, from the lowest: compounds 1, 3, 4 and 2 (each within the scatter of the next, the first and the last beyond it).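

In this assay, taking acetamidomethyl off this aromatic carbon gives a step within the scatter (a 2.0-fold lower number from compound 2 to compound 4 (0.30 log units; within the scatter)), so this pair shows no clear dependence on that group. Hydroxymethyl is different, since the change to hydrogen gives a step beyond the scatter (a 4.0-fold higher number from compound 1 to compound 4 (0.60 log units; beyond the scatter)), the first sign that a substituent on this biphenyl-like end can count. Nothing available explains this contrast.

Open, as far as these compounds go, is whether an amine or a carboxylic acid on this aromatic carbon would move the number beyond the scatter from compound 4. A longer chain there is equally untested in the compounds shown.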